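A few compounds are considered here, and "the series" means these few. Any claim that something is new, unique, unknown or untested is made for them only; others in the source may bear on it.

The shared core appears first in compound 1 `O=C(Nc1ccc(Oc2ccnc3[nH]ccc23)c(F)c1)c1ccc(-c2ccc(Cl)cc2)cn1`. In a functional assay on PC-3 cells (Homo sapiens) for cytotoxicity, read by MTT assay, with a stated time of 72 h (a lower number here means a stronger inhibitor, a higher number a weaker inhibitor), compound 1 gives 3030 nM. Compound 2 `O=C(Nc1ccc(Oc2ccnc3[nH]ccc23)c(F)c1)c1cc(-c2ccccc2)ccn1` differs from compound 1 in more than one place, so the two values are simply shown side by side. In this assay compound 2 gives > 10000 nM, which is a limit of the assay and not a number (the limit of > 10000 nM in this assay, at which 1 of the 2 values shown sits). Compound 2 thus stands at the weak end of what has been measured, and only that limit is known for it. Compound 3 `O=C(Nc1ccc(Oc2ccnc3[nH]ccc23)c(F)c1)c1cc(-c2ccc(C(F)(F)F)cc2)ccn1` has not yet been measured. It differs from compound 2 by trifluoromethyl in place of hydrogen on an aromatic carbon. Among the compounds with values here, no measured pair shows this change, so its direction and size remain open. The most that can be expected for compound 3 is a move into the measurable range, and the expected step is an at least 1.2-fold lower number from compound 2 to compound 3 (0.09 log units; that floor lies within the scatter). Compound 3 is estimated at 8000 nM, with a range from 2500 nM to 30000 nM.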

Compound 3, half-maximal inhibitory concentration: 4350 nM
Compound 3: the middle estimate sits 1.8-fold (0.26 log units) above what was measured, and the stated range covers the measured number.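

Trifluoromethyl on an aromatic carbon of the phenyl ring, para to a large group, gives the first reading of this position in this assay: the change from phenyl to 4-(trifluoromethyl)phenyl brings an at least 2.2-fold lower number from compound 2 to compound 3 (0.36 log units; beyond the scatter). The step is a floor and not a full size, because compound 2 is held at a limit of the assay and not at a number: the limit of > 10000 nM in this assay, at which 1 of the 3 values shown sits. Even so, the pair shows that this position is not silent, since a single substituent here is enough to bring the series from that limit into the measurable range, although this rests on one pair alone.

The compounds shown do not tell whether this gain belongs to trifluoromethyl in particular or would also come with another group at the same place, such as an amine, a methoxy group or a carboxylic acid. They also leave open how large the step truly is, and whether the same change would act in the same direction on a phenyl ring attached elsewhere on the shared core.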